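The compounds below may be only part of what the source reports. "The series", "measured", "known", "first", "only" and "open" are said of these compounds alone.

Of the compounds shown here, three built on a shared core have been tested in a functional assay on NCI-H322M cells (Homo sapiens) for inhibition, read by sulforhodamine B assay, with a stated time of 48 h, tested at 100 uM; on this read-out higher numbers stand for a weaker effect at the one concentration tested and lower numbers for a stronger effect. Compound 1 `O=C(Nc1cccc(-n2cc(-c3ccncc3)c(-c3cc(O)cc(Cl)c3)n2)c1)Nc1ccc(Cl)c(C(F)(F)F)c1` gives -81% in this assay. Compound 2 `O=C(Nc1cccc(-n2cc(-c3ccncc3)c(-c3cc(O)cc(Cl)c3)n2)c1)Nc1ccc(Cl)c(Cl)c1` gives -24% in this assay. Compound 3 `COc1cc(Cl)cc(-c2nn(-c3cccc(NC(=O)Nc4cc(C(F)(F)F)cc(C(F)(F)F)c4)c3)cc2-c2ccncc2)c1` gives -78% in this assay. Among these three numbers compound 3 stands second highest: its number sits near that of compound 1, within the usual scatter, and far from that of compound 2, a gap beyond the scatter. Within the data shown here, the single step between measured compounds, a number 57 percentage points higher from compound 1 to compound 2 (beyond the scatter), came with a chloro in place of a trifluoromethyl on an aromatic carbon, and the effect became much weaker.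

Compound 4 `COc1cc(Cl)cc(-c2nn(-c3cccc(NC(=O)Nc4cccc(C(F)(F)F)c4)c3)cc2-c2ccncc2)c1` has not yet been measured. It differs from compound 3 as follows: hydrogen in place of trifluoromethyl on an aromatic carbon. Once more a trifluoromethyl group is lost, though here a hydrogen enters rather than a chloro, and compound 4 still keeps one trifluoromethyl group. Because a number 57 percentage points higher from compound 1 to compound 2 (beyond the scatter) accompanied the loss of a trifluoromethyl, a rise toward a weaker effect is expected for compound 4 in this assay, possibly smaller than that step. The expected step is a number 38 percentage points higher from compound 3 to compound 4 (beyond the scatter). The estimate for compound 4 in this assay is therefore -40%, within a range from -80% to 0%.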

Compound 4, a percentage reported as activity, at one concentration (the size of the read-out at that concentration, not a potency): -8%
Compound 4: the middle estimate sits 32 percentage points below what was measured; low and high end bracket the measured number.
By their numbers in this assay, from the lowest: compounds 1 and 3 (each within the scatter of the next); then compound 2; then compound 4.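

Swapping one trifluoromethyl for hydrogen on the urea-bearing end of compound 3 comes with a number 70 percentage points higher from compound 3 to compound 4 (beyond the scatter) in this assay and so shows that, in this compound, a single remaining trifluoromethyl group does not keep the effect in place. The earlier step showed a large change when a chloro entered in place of a trifluoromethyl, whereas here a large change follows when four heavy atoms leave and no heavy atom enters, so both listed removals of a trifluoromethyl go the same way, toward a weaker effect, and neither compound pair goes against this. Nothing measured here tells why this group matters so much at this position.

Going by these compounds, it stays open whether a smaller group at this place, such as a methyl group, a fluorine or a nitrile, would give back part of the effect seen with compound 3, or whether only the trifluoromethyl does so. On these data alone, it also stays open whether an amine or a carboxylic acid could be tolerated there, and whether the same swap to hydrogen would carry the same weight on the core of compound 1, which bears a hydroxyl where compound 3 bears a methoxy group.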